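Methoxy in place of hydrogen: outlook for compound 3

The source may report more compounds than this note shows. Statements on the series, on what has been measured and on what is new or still open speak of the compounds shown alone.

Compound 1 `CN1CCC/C1=N\C(=O)Nc1cccc(C(F)(F)F)c1` gives in a functional assay on the whole organism with Rattus norvegicus as the target, with a stated time of 5 days (on this read-out lower numbers stand for an effect already at smaller amounts and higher numbers for an effect only at larger amounts of compound), only a limit of the assay, > 25 mg/kg; this is the limit of > 25 mg/kg in this assay, at which 1 of the 2 values shown sits. Going by the values given here, compound 2 `CN1CCC/C1=N\C(=O)Nc1ccccc1` gives in this assay 15 mg/kg, the only number so far. Among the compounds with values here, the single measured step, an at least 1.6-fold lower number from compound 1 to compound 2 (0.22 log units; that floor lies within the scatter), comes from hydrogen in place of trifluoromethyl on an aromatic carbon, and because one end of it is the limit of > 25 mg/kg in this assay, at which 1 of the 2 values shown sits, its true size is open.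

Compound 3 `COc1cccc(NC(=O)/N=C2\CCCN2C)c1` differs from compound 2 as follows: methoxy in place of hydrogen on an aromatic carbon. The change sits on the same aromatic carbon that carried trifluoromethyl in compound 1 and hydrogen in compound 2. Within the data shown here, the only step that bears on it runs at the limit of the assay, so it sets no direction for an entering methoxy. With no further guidance, a step that stays within the scatter is expected, with some chance of a limit again. Compound 3 is therefore expected to give 20 mg/kg in this assay, between 8 mg/kg and 50 mg/kg. The step expected from compound 2 to compound 3 is a 1.3-fold higher number from compound 2 to compound 3 (0.12 log units; within the scatter).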

Compound 3, minimum effective dose: > 25 mg/kg
Compound 3: no number, only a limit (the forecaster's own chance of this, stated with the estimate: 30%); at least 1.2-fold (0.09 log units) between middle value and limit.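

The position, meta to a large group, now carries two different groups, trifluoromethyl in compound 1 and methoxy in compound 3; in this assay both compounds stop at a limit of the assay, and the step between them cannot be read. For methoxy in place of hydrogen the result gives an at least 1.6-fold higher number from compound 2 to compound 3 (0.22 log units; that floor lies within the scatter), and as this floor lies within the scatter, it does not establish that methoxy weakens the effect relative to hydrogen, though it gives no sign of a gain at the dose tested. The true size of this step stays open because one of its ends is a limit, which also leaves compound 2 as the only compound with a number and no measured rank among the substituents: the limit of > 25 mg/kg in this assay, at which 2 of the 3 values shown sit.

The compounds shown leave open whether fluorine, methyl, an amine or a carboxylic acid on this aromatic carbon would give a number in this assay rather than a limit. Also open, as far as these compounds go, is whether methoxy or trifluoromethyl on another carbon of the same ring would end at a limit as well.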